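The source may report more compounds than this note shows. Statements on the series, on what has been measured and on what is new or still open speak of the compounds shown alone.

Measured so far:
compound 1, `COc1ccc(-c2nc(Cc3c[nH]c4ccccc34)no2)cc1`
compound 2, `COc1cc(-c2noc(-c3ccccc3)n2)cc(OC)c1OC`

In a functional assay on cells (Splenocyte, Mus musculus, strain BALB/c) for inhibition, read by scintillation counting and thymidine incorporation, with stated times of 48 h and 8 h (a lower number here means a stronger inhibitor, a higher number a weaker inhibitor), compound 1 gives > 50000 nM, which is a limit of the assay rather than a number. Compound 2 gives > 50000 nM in this assay, again only a limit. Compound 2 thus stands at the limit of > 50000 nM in this assay, at which 2 of the 2 values shown sit, with no measured value to rank it against. Compound 3, `CCc1ccc(-c2nc(-c3cc(OC)c(OC)c(OC)c3)no2)cc1`, differs from compound 2 by ethyl in place of hydrogen on an aromatic carbon. Going by the values given here, no step between measured compounds exists to calibrate such a change. The expected step is a step that the limit leaves unreadable from compound 2 to compound 3, nothing beyond the scatter. Compound 3 is estimated at 60000 nM, between 10000 nM and 300000 nM.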

Compound 3, half-maximal inhibitory concentration: > 50000 nM
Compound 3 was reported as a limit; the forecaster's own chance of this, stated with the estimate: 80%; the middle value lies beyond the limit too.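

No step can be read from compound 2 to compound 3, since each stands only as a limit: the limit of > 50000 nM in this assay, at which 3 of the 3 values shown sit.

The compounds shown leave open whether ethyl in place of hydrogen on an aromatic carbon changes inhibition at all.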